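The compounds below may be only part of what the source reports. "The series", "measured", "known", "first", "only" and "open" are said of these compounds alone.

Measured so far in a functional assay on HepG2 cells (Homo sapiens) for antiproliferative activity, read by MTT assay, with a stated time of 24 h; on this read-out lower numbers stand for stronger inhibition and higher numbers for weaker inhibition:
- compound 1 `O=c1[nH]cc(S(=O)(=O)Nc2ccccc2-c2cn(-c3ccccc3F)nn2)c(=O)[nH]1`: 12500 nM
- compound 2 `O=c1[nH]cc(S(=O)(=O)Nc2ccc(-c3cn(-c4ccccc4)nn3)cc2)c(=O)[nH]1`: 18000 nM
- compound 3 `Cc1ccccc1-n1cc(-c2ccc(NS(=O)(=O)c3c[nH]c(=O)[nH]c3=O)cc2)nn1`: 14500 nM

On this assay the three numbers lie close together. Compound 3 sits between the other two, its gap to compound 1 and its gap to compound 2 both within the scatter, so none of the three can be set apart from the others.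

Going by the values given here, the one single-point step measured so far is a 1.2-fold lower number from compound 2 to compound 3 (0.09 log units; within the scatter), a methyl added to an aromatic carbon, and it did not move the number beyond the scatter.

Compound 4 `Cc1cccc(-n2cc(-c3ccc(NS(=O)(=O)c4c[nH]c(=O)[nH]c4=O)cc3)nn2)c1` is the next step from compound 3: 3-methylphenyl in place of 2-methylphenyl on an aromatic nitrogen. The methyl stays, its position on the phenyl ring moves. Among the compounds with values here, the step from compound 2 to compound 3 is the only one that bears on a methyl on this ring, and it was flat; nothing among the measured compounds suggests that shifting the methyl would do more than adding it did. The expected step is therefore a 1.0-fold higher number from compound 3 to compound 4 (0.01 log units; within the scatter), in no particular direction beyond the scatter.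

The estimate for compound 4 in this assay is 15000 nM, with a range from 8000 nM to 30000 nM.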

Compound 4, half-maximal inhibitory concentration: > 20000 nM
Compound 4: only a limit was reported (the forecaster's own chance of this, stated with the estimate: 10%); at least 1.3-fold (0.12 log units) between middle value and limit.
By their numbers in this assay, from the lowest: compounds 1, 3 and 2 (each within the scatter of the next). At a limit, above all of these: compound 4.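

In this assay compound 4 is reported only as a limit, > 20000 nM, and the change on the aromatic nitrogen therefore has no exact size. The step for 3-methylphenyl in place of 2-methylphenyl is an at least 1.3-fold higher number from compound 3 to compound 4 (0.13 log units; that floor lies within the scatter), and the step for the methyl as it stands in 3-methylphenyl is an at least 1.1-fold higher number from compound 2 to compound 4 (0.04 log units; that floor lies within the scatter); both are floors, and neither shows a real effect of the methyl or of its position on the phenyl ring. What is new is modest: moving the methyl to this ring position does not bring the number down, and compound 4 is the only compound of the set reported at a limit: the limit of > 20000 nM in this assay, at which 1 of the 4 values shown sits.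

As far as these compounds go, how far the true value of compound 4 lies past that limit stays open, and with it whether the position of the methyl matters by more than the scatter. Also open, from the compounds shown here alone, is whether a methoxy group or an amine on this phenyl ring would give any number clearly apart from those of the methyl compounds in this assay.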